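This account rests on a few compounds, and the source may have more. Where it says the series, first, only, none or still open, it means among the compounds named here.

Compound 1 `O=C(O)CCCCCC[C@@H]1[C@@H](CC[C@@H](O)CCc2cccc(F)c2)[C@H](O)C[C@@H]1O` is the stronger of the two measured compounds here. In an in vitro assay on CHO-KI cells for displacement of a labelled ligand from prostaglandin F2-alpha receptor (Homo sapiens) (on this read-out higher numbers stand for weaker inhibition and lower numbers for stronger inhibition), compound 1 gives 42 nM, the lowest of the two numbers, while compound 2 `Cc1ccc(CC[C@H](O)CC[C@@H]2[C@@H](CCCCCCC(=O)O)[C@@H](O)C[C@H]2O)cc1` gives 4400 nM. The step of a 100-fold higher number from compound 1 to compound 2 (2.02 log units; beyond the scatter) shows that exchanging the aromatic group on a saturated chain carbon, three bonds along the chain from an oxygen on a saturated carbon, can shift the result strongly. Compound 3 `COc1ccccc1CC[C@H](O)CC[C@@H]1[C@@H](CCCCCCC(=O)O)[C@@H](O)C[C@H]1O` carries a different exchange at the same place: 2-methoxyphenyl in place of 3-fluorophenyl on a saturated chain carbon, three bonds along the chain from an oxygen on a saturated carbon. Among the measured compounds shown here, only one measured step bears on this change, and it was large and in the weakening direction, although the group entering in compound 2 is not the group entering in compound 3, so the size of the effect here is uncertain. The step of a 9.5-fold higher number from compound 1 to compound 3 (0.98 log units; beyond the scatter) is therefore expected to run in the weakening direction, smaller than the measured one, with a wide range around it. Compound 3 is expected to give about 400 nM in this assay, with a range from 60 nM to 3000 nM.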

Compound 3, half-maximal inhibitory concentration: 5890 nM
Estimate against measurement, compound 3: 15-fold (1.17 log units) below; measured number outside the range, above it.
By their numbers in this assay, from the lowest: compound 1; then compounds 2 and 3 (each within the scatter of the next).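

In this assay the step of a 140-fold higher number from compound 1 to compound 3 (2.15 log units; beyond the scatter) shows that the large loss seen with 4-methylphenyl is not tied to that one group, since 2-methoxyphenyl at the same place also leaves the number far higher than with 3-fluorophenyl. The step of a 1.3-fold higher number from compound 2 to compound 3 (0.13 log units; within the scatter) adds that these two replacements cannot be told apart in this assay, so among the three compounds shown only the one carrying 3-fluorophenyl gives the low number. Nothing given here explains why compound 1 stands apart from the other two.

The compounds shown leave open whether the low number depends on the fluorine itself or on where a group sits on the ring, since each exchange alters both the group and its place on the ring at once. Answers could come from the same core carrying 3-methoxyphenyl, 3-methylphenyl, 2-fluorophenyl or 4-fluorophenyl, which would separate the kind of group from its place, or plain phenyl, which would show what the ring does with nothing on it.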